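The source may report more compounds than this note shows. Statements on the series, on what has been measured and on what is new or still open speak of the compounds shown alone.

The measured compounds:
Compound 1 `NC(=O)c1c(NC(=O)c2ccccc2F)sc2c1CCN(C(=S)Nc1ccccc1Cl)C2` – 19400 nM in a functional assay on HeLa cells (Homo sapiens) for antiproliferative activity, with a stated time of 24 h; a lower number here means a stronger inhibitor, a higher number a weaker inhibitor
Compound 2 `NC(=O)c1c(NC(=O)c2ccccc2Br)sc2c1CCN(C(=S)Nc1ccccc1Cl)C2` – 46900 nM in this assay

Among the compounds with values here, compound 2 carries the higher of the two numbers in this assay; its only neighbour is compound 1, and the pair is separated by a 2.4-fold higher number from compound 1 to compound 2 (0.38 log units; beyond the scatter). Compound 3 `NC(=O)c1c(NC(=O)c2ccccc2I)sc2c1CCN(C(=S)Nc1ccccc1Cl)C2` has not been measured. It differs from compound 2 in one place: iodo in place of bromo on an aromatic carbon. Within the data shown here, one measured step concerns the same aromatic carbon, namely a 2.4-fold higher number from compound 1 to compound 2 (0.38 log units; beyond the scatter), a modest step toward the weaker side. Among the measured compounds shown here, that step is the sole guide, and it involves a different pair of halogens, so it can be carried over only loosely. Compound 3 is therefore expected to sit near compound 2 or somewhat above it. The estimated step is a 1.3-fold higher number from compound 2 to compound 3 (0.11 log units; within the scatter). The estimate for compound 3 in this assay is 60000 nM, with a range from 25000 nM to 150000 nM.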

Compound 3, half-maximal inhibitory concentration: > 50000 nM
Compound 3 ended at the assay's limit (the forecaster's own chance of this, stated with the estimate: 20%); the middle value lies beyond the limit too.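

In this assay compound 3 gives > 50000 nM, which is a limit and not a number, so the 2-iodophenyl group brings this series to the edge of what the assay can read: the limit of > 50000 nM in this assay, at which 1 of the 3 values shown sits. Against bromo the change reads as an at least 1.0-fold higher number from compound 2 to compound 3 (0.02 log units; that floor lies within the scatter), so it cannot settle whether iodo differs from bromo at this aromatic carbon. Against fluoro it reads as an at least 2.5-fold higher number from compound 1 to compound 3 (0.41 log units; beyond the scatter), which extends the earlier finding: of the three halogens, fluoro gives the lowest number, and neither bromo nor iodo comes back to it.

The compounds shown leave open how far past the limit compound 3 truly lies. They also leave open whether chloro, plain hydrogen, a methoxy group or an amine on this carbon would give a lower number than fluoro.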